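This account rests on a few compounds, and the source may have more. Where it says the series, first, only, none or still open, it means among the compounds named here.

Of the compounds shown here, three have been measured in a functional assay on MNK45 cells (Homo sapiens) for inhibition, read by MTT assay, with a stated time of 48 h; a lower number here means a stronger inhibitor, a higher number a weaker inhibitor. Compound 1 `Cc1ccc(NC(=S)NC(=O)c2ccc(OCc3ccc(Cl)c(Cl)c3)cc2)cc1-c1nc2ccccc2[nH]1` gives 8410 nM. Compound 2 `Cc1ccc(NC(=S)NC(=O)c2ccc(OCc3ccc(Cl)cc3Cl)cc2)cc1-c1nc2ccccc2[nH]1` gives 5300 nM. Compound 3 `Cc1ccc(NC(=O)NC(=O)c2ccc(OCc3ccc(Cl)c(Cl)c3)cc2)cc1-c1nc2ccccc2[nH]1` gives 5820 nM.

Compound 1 and compound 2 share one core and differ in a single place: 2,4-dichlorophenyl in place of 3,4-dichlorophenyl on a saturated chain carbon bound to an oxygen on an aromatic ring. That change gave a 1.6-fold lower number from compound 1 to compound 2 (0.20 log units; within the scatter). Compound 3 stands on a second core; how the two cores differ is not broken down here. Compound 4 `Cc1ccc(NC(=O)NC(=O)c2ccc(OCc3ccc(Cl)cc3Cl)cc2)cc1-c1nc2ccccc2[nH]1` has not yet been measured. It differs from compound 3 by 2,4-dichlorophenyl in place of 3,4-dichlorophenyl on a saturated chain carbon bound to an oxygen on an aromatic ring, the same change that separates compound 1 from compound 2, made at the same place.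

Within the data shown here, on that basis the step to compound 4 is expected to be about a 1.5-fold lower number from compound 3 to compound 4 (0.16 log units; within the scatter) in this assay, because the one earlier instance of this change gave a 1.6-fold lower number from compound 1 to compound 2 (0.20 log units; within the scatter). The account rests on a single pair, so the expectation is loose. Compound 4 is estimated at 4000 nM in this assay.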

Compound 4, half-maximal inhibitory concentration: 2550 nM
For compound 4 the middle estimate is 1.6-fold (0.20 log units) above the measured one, within the range that was stated.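

In this assay, putting 2,4-dichlorophenyl in place of 3,4-dichlorophenyl on the core of compound 3 gave a 2.3-fold lower number from compound 3 to compound 4 (0.36 log units; beyond the scatter). Set beside the same change on the core of compound 1, the two steps run the same way and do not differ in size beyond the scatter: the same change on two cores in this assay, a 1.6-fold lower number (0.20 log units; within the scatter) from compound 1 to compound 2 and a 2.3-fold lower number (0.36 log units; beyond the scatter) from compound 3 to compound 4, 1.4-fold (0.16 log units) apart, within the scatter of two such steps. This shows that the change carried from one core to the other in these two pairs, but the step on the core of compound 1 is itself within the scatter, and two pairs in one cell assay do not show that it would hold on other cores.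

The compounds shown carry only dichlorophenyl groups on the saturated chain carbon, so it remains open how a fluorophenyl or an unsubstituted phenyl would read in this assay. Also open, as far as these compounds go, is what a longer chain in place of that saturated chain carbon would do.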